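The compounds below may be only part of what the source reports. "The series", "measured", "known", "first", "only" and "open" are said of these compounds alone.

Three compounds built around a lipoic-acid amide linked through a triazole to a coumarin have been tested in a functional assay on PC-12 cells (Rattus norvegicus) for cytotoxicity, read by MTT assay, with stated times of 3 h and 2 h, tested at 0.1 uM; on this read-out lower numbers stand for a weaker effect and higher numbers for a stronger effect at the one concentration tested. Compound 1 `O=C(CCCCC1CCSS1)NCc1cn(CCCCOc2ccc3cc(-c4ccccc4)c(=O)oc3c2)nn1` gives 38.6%. Compound 2 `COc1ccc(-c2cc3ccc(OCCCCn4cc(CNC(=O)CCCCC5CCSS5)nn4)cc3oc2=O)cc1` carries the change methoxy in place of hydrogen on an aromatic carbon and gives 32.1%, so the step of a number 6.5 percentage points lower from compound 1 to compound 2 (within the scatter). Compound 3 `COc1ccc(-c2cc3ccc(OCCCCCn4cc(CNC(=O)CCCCC5CCSS5)nn4)cc3oc2=O)cc1` gives 34.5%; the difference between the core of compound 3 and the core of compound 1 is not broken down here, and the two values lie within the scatter of each other.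

Compound 4 `COc1ccc(-c2cc3ccc(OCCCCCn4cc(CNC(=O)CCCCC5CCSS5)nn4)cc3oc2=O)cc1OC` has not yet been measured. It differs from compound 3 by methoxy in place of hydrogen on an aromatic carbon. This is the same kind of change as that from compound 1 to compound 2, but the place is not the same: in compound 4 the new group sits ortho to a methoxy group and meta to a large group, whereas in compound 2 it sits para to a large group. Because the earlier step was a number 6.5 percentage points lower from compound 1 to compound 2 (within the scatter), the step from compound 3 to compound 4 is expected to be small, about a number 2.5 percentage points lower from compound 3 to compound 4 (within the scatter). Compound 4 is estimated to give 32% in this assay, within roughly 22% to 42%.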

Compound 4, a percentage reported as activity, at one concentration (the size of the read-out at that concentration, not a potency): 38.5%
Beside the measured number, compound 4's estimate is 6.5 percentage points below it; the measured number falls inside the stated range.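

Replacing hydrogen with methoxy on the aromatic ring, here 4-methoxyphenyl to 3,4-dimethoxyphenyl, gives a number 4 percentage points higher from compound 3 to compound 4 (within the scatter) in this assay. Set beside the earlier step on the other core, the change reads alike as far as this measurement can tell: the same change on two cores in this assay, a number 6.5 percentage points lower (within the scatter) from compound 1 to compound 2 and a number 4 percentage points higher (within the scatter) from compound 3 to compound 4, 10.5 percentage points apart, within the scatter of two such steps This shows that on both cores the methoxy change leaves the read-out within the usual scatter, so the opposite directions of the two steps carry no weight; it does not show that the change would stay this small on another core, at another place on the ring, or at another concentration.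

The compounds shown leave open whether a different group at this place on the ring, such as a hydroxyl or an amine, would move the read-out beyond the scatter. They also leave open what a longer chain between the triazole and the coumarin would do.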